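A few compounds are considered here, and "the series" means these few. Any claim that something is new, unique, unknown or untested is made for them only; others in the source may bear on it.

Measured in a functional assay on cells (Homo sapiens) for antiproliferative activity, read by CellTiter-Glo, with a stated time of 96 h; on this read-out lower numbers stand for stronger inhibition and higher numbers for weaker inhibition:
- Compound 1 `COc1ccc(-c2nsc3c2NC(=O)CC3c2cccc(OC)c2)cc1`: 1910 nM.
- Compound 2 `COc1ccc(-c2nsc3c2NC(=O)CC3c2cccc(F)c2)cc1`: > 2000 nM, a limit.
- Compound 3 `COc1ccc(-c2nsc3c2NC(=O)CC3c2ccc(F)cc2)cc1`: > 2000 nM, a limit.

Compound 3 therefore has no number, only a limit. The readings so far crowd at the limit of > 2000 nM in this assay, at which 2 of the 3 values shown sit.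

Compound 4 `COc1ccc(-c2nsc3c2NC(=O)CC3c2ccsc2)cc1` differs from compound 3 as follows: thiophen-3-yl in place of 4-fluorophenyl on a saturated ring carbon. The nearest measured changes on this saturated ring carbon are an at least 1.0-fold higher number from compound 1 to compound 3 (0.01 log units; that floor lies within the scatter) and a step that the two limits leave unreadable from compound 2 to compound 3. Neither shows a size beyond the scatter, so neither supports a shift in either direction.

In this assay the expected step is a number no higher from compound 3 to compound 4 (the limit leaves the size open), with no clear change anticipated. The estimate for compound 4 is 2000 nM, with an expected range of 900 nM to 4500 nM, and a further limit is quite possible.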

Compound 4, half-maximal inhibitory concentration: 309 nM
For compound 4 the middle estimate is 6.5-fold (0.81 log units) above the measured one; measured number outside the range, below it.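

For the compounds shown here, on the saturated ring carbon, thiophen-3-yl gives the first step beyond the scatter in this assay, with an at least 6.4-fold lower number from compound 3 to compound 4 (0.81 log units; beyond the scatter) and an at least 6.4-fold lower number from compound 2 to compound 4 (0.81 log units; beyond the scatter), both floors set by limits. Against the 3-methoxyphenyl group, the only earlier compound with a number, the step is a 6.2-fold lower number from compound 1 to compound 4 (0.79 log units; beyond the scatter). This position therefore responds to the choice of ring, which the phenyl-bearing compounds alone did not show.

From the compounds shown here alone, whether the gain follows the five-membered ring or its sulfur stays open. Going by these compounds, how a furan-3-yl or pyridin-3-yl group would read at this carbon also stays open.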